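Configuration changes in the series: compound 2 to compound 3

The source may report more compounds than this note shows. Statements on the series, on what has been measured and on what is new or still open speak of the compounds shown alone.

Values in an ADME assay on HFF cells (Homo sapiens) for cytotoxicity, read by neutral red uptake; a lower number here means that less compound is tolerated, a higher number that more compound is tolerated:
compound 1 `Nc1ncnc2c1ncn2/C=C1\C[C@H]1[C@H](O)CO`: 194000 nM
compound 2 `Nc1ncnc2c1ncn2/C=C1\C[C@H]1[C@@H](O)CO`: 264000 nM

For the measured compounds named here, compound 2 cannot be told apart from its one neighbour: a 1.4-fold higher number from compound 1 to compound 2 (0.13 log units; within the scatter). Compound 3 `Nc1ncnc2c1ncn2/C=C1/C[C@@H]1[C@@H](O)CO` brings a further change of configuration: the two compounds have the same atoms and bonds and differ only in configuration as drawn: 2 of 3 stereo elements differ; a stereocentre at a saturated ring carbon is drawn R in compound 2 and S in compound 3; a double bond is drawn E in compound 2 and Z in compound 3. Going by the values given here, the one measured step rests on the fact that compounds 1 and 2 differ only in the configuration as drawn and touched a saturated chain carbon. Among the compounds with values here, the saturated ring carbon and the double bond have no measured step of their own. In this assay no shift beyond the scatter and no direction is expected, and the estimated step is a 1.2-fold lower number from compound 2 to compound 3 (0.08 log units; within the scatter). For compound 3 the expected value is 220000 nM, with an estimated range of 100000 nM to 400000 nM.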

Compound 3, half-maximal cytotoxic concentration: > 300000 nM
Compound 3 ended at the assay's limit; the forecaster's own chance of this, stated with the estimate: 25%; middle value at least 1.3-fold (0.13 log units) away from the limit.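

In this assay compound 3 reads > 300000 nM, a limit of the assay and not a number. The saturated ring carbon and the double bond, changed together, give an at least 1.1-fold higher number from compound 2 to compound 3 (0.05 log units; that floor lies within the scatter), and all three stereo elements changed together give an at least 1.5-fold higher number from compound 1 to compound 3 (0.18 log units; that floor lies within the scatter). Both floors lie within the scatter, so the configurations shown are not separated, although the true size of each step remains unknown.

The ring carbon and the double bond change only jointly here, so neither has a separate step. As far as these compounds go, how a carboxylic acid or a longer chain on the shared core would read in this assay also remains open.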